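The source may hold more compounds than are shown below. What is called first, only, known or untested is meant among the compounds shown, and "the series" means these compounds.

In an assay on cells for agonist activity at vitamin D3 receptor (Homo sapiens), with a stated time of 96 h (on this read-out lower numbers stand for an effect already at smaller amounts and higher numbers for an effect only at larger amounts of compound), three compounds of one series have been measured so far. Compound 1 `CCC(C)C(NC(=O)c1ccc(C(CC)(CC)c2ccc(OCCC(O)(CC)CC)c(C)c2)n1CC)C(=O)OC` gives > 10000 nM, which is a limit of the assay and not a number. Compound 2 `CCn1c(C(=O)NC(C)C(=O)O)ccc1C(CC)(CC)c1ccc(OCCC(O)(CC)CC)c(C)c1` gives 66 nM, and compound 3 `CCC(C)C(CO)NC(=O)c1ccc(C(CC)(CC)c2ccc(OCCC(O)(CC)CC)c(C)c2)n1CC` gives 450 nM. Among the two numbers shown, compound 3 therefore stands highest; its nearest neighbour is compound 2, with a 6.8-fold higher number from compound 2 to compound 3 (0.83 log units; beyond the scatter). The two steps that start from compound 1, an at least 150-fold lower number from compound 1 to compound 2 (2.18 log units; beyond the scatter) and an at least 22-fold lower number from compound 1 to compound 3 (1.34 log units; beyond the scatter), rest on the limit of > 10000 nM in this assay, at which 1 of the 3 values shown sits, and are read as lower bounds.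

Compound 4 `CCn1c(C(=O)NC(CO)CCO)ccc1C(CC)(CC)c1ccc(OCCC(O)(CC)CC)c(C)c1` differs from compound 3 by 2-hydroxyethyl in place of sec-butyl on a saturated chain carbon bound to an amide-type nitrogen and a saturated chain carbon. Among the compounds with values here, no measured step makes this exact change. The steps that touch compound 3 are an at least 22-fold lower number from compound 1 to compound 3 (1.34 log units; beyond the scatter), which alters the other substituent on the same carbon, and a 6.8-fold higher number from compound 2 to compound 3 (0.83 log units; beyond the scatter), where the 1-carboxyethyl side chain of compound 2 goes with the lower number. Since compound 4 again carries a shorter side chain on the amide nitrogen and compound 2 gives 66 nM, a modest lowering of the number is expected, a 1.8-fold lower number from compound 3 to compound 4 (0.26 log units; within the scatter). For compound 4 the estimate in this assay is 250 nM, with a range from 70 nM to 900 nM.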

Compound 4, half-maximal effective concentration: 2490 nM
Compound 4: middle estimate off by 10-fold (1.00 log units), on the low side; the whole stated range lies below it.
By their numbers in this assay, from the lowest: compound 2; then compound 3; then compound 4. At a limit, above all of these: compound 1.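

In this assay, within the data shown here, the step of a 5.5-fold higher number from compound 3 to compound 4 (0.74 log units; beyond the scatter) is the first measured change to the sec-butyl group itself, as the earlier steps at this carbon altered only its other substituent, and 2-hydroxyethyl moves the number up, not down. A shorter side chain on the amide nitrogen therefore does not by itself give a lower number, as a 38-fold higher number from compound 2 to compound 4 (1.58 log units; beyond the scatter) also shows. Among these compounds, compound 2 remains the only compound with a lower number than compound 3, which gives 450 nM. The step that starts from a limit, an at least 4.0-fold lower number from compound 1 to compound 4 (0.60 log units; beyond the scatter), reads only as a lower bound: the limit of > 10000 nM in this assay, at which 1 of the 4 values shown sits.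

The compounds shown do not separate the hydroxyl from the shorter chain, which a plain ethyl or a 2-methoxyethyl on this carbon could address. On these data alone, it also remains open how a carboxylic acid in place of the hydroxymethyl would read alongside sec-butyl or 2-hydroxyethyl.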